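Restoring the hydroxy ortho to the hydrazone carbon

The compounds below may be only part of what the source reports. "The series", "measured", "known", "first", "only" and "open" are said of these compounds alone.

Compound 1, `C/C(=N\NC(=O)c1cccc(S(=O)(=O)N2CCOCC2)c1)c1ccccc1O`: 5400 nM
Compound 2, `C/C(=N\NC(=O)c1cccc(S(=O)(=O)N2CCOCC2)c1)c1cccc(O)c1`: > 100000 nM

In a functional assay on MCF7 cells (Homo sapiens) for antiproliferative activity, read by MTT assay, with a stated time of 72 h (on this read-out higher numbers stand for weaker inhibition and lower numbers for stronger inhibition), compound 1 gives 5400 nM. For compound 2 the value > 100000 nM is a limit of the assay and not a number, so compound 2 sits at the limit of > 100000 nM in this assay, at which 1 of the 2 values shown sits. The step of an at least 18-fold higher number from compound 1 to compound 2 (1.26 log units; beyond the scatter) shows that exchanging 2-hydroxyphenyl for 3-hydroxyphenyl cost a large amount of inhibition.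

Compound 3, `C/C(=N\NC(=O)c1cccc(S(=O)(=O)N2CCOCC2)c1)c1cc(O)ccc1O`, differs from compound 2 by hydroxy in place of hydrogen on an aromatic carbon; read one bond further out, 3-hydroxyphenyl becomes 2,5-dihydroxyphenyl, so the hydroxy ortho to a large group that compound 1 carries is present again, while the hydroxy of compound 2 is kept. Within the data shown here, only the step from compound 1 to compound 2 bears on this change, and it was large; undoing it points to a large step back toward stronger inhibition. The expected step is an at least 12-fold lower number from compound 2 to compound 3 (1.09 log units; beyond the scatter). Compound 3 is therefore estimated at about 8000 nM, within 2000 nM to 60000 nM.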

Compound 3, half-maximal inhibitory concentration: > 100000 nM
Compound 3: no number, only a limit (the forecaster's own chance of this, stated with the estimate: 20%); middle value at least 12-fold (1.09 log units) away from the limit.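

In this assay compound 3 gives > 100000 nM, which is a limit of the assay and not a number. Having the hydroxy ortho to a large group is therefore not enough by itself to keep inhibition: going from 2-hydroxyphenyl to 2,5-dihydroxyphenyl, with one added hydroxy, gives an at least 18-fold higher number from compound 1 to compound 3 (1.26 log units; beyond the scatter). The step between compound 2 and compound 3 cannot be read, as both stand at the same limit: the limit of > 100000 nM in this assay, at which 2 of the 3 values shown sit.

From the compounds shown here alone, how far compound 2 and compound 3 lie past that limit remains open, so neither can be ranked against the other. Also open, going by these compounds, is whether the loss belongs to the hydroxy alone, or whether a methoxy group or an amine at the same place on the 2-hydroxyphenyl group would bring a similar loss.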